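The compounds below may be only part of what the source reports. "The series", "measured", "known", "first", "only" and "open" are said of these compounds alone.

Measured so far:
- compound 1 `CN(C)CCn1cnnc1-c1cc(Oc2ccc(NC(=O)N/N=C/c3cccc(O)c3)cc2F)ccn1`: > 100000 nM
- compound 2 `CN(C)CCn1cnnc1-c1cc(Oc2ccc(NC(=O)N/N=C/c3c[nH]c4ccccc34)cc2F)ccn1`: 690 nM
- compound 3 `Cn1cnnc1-c1cc(Oc2ccc(NC(=O)N/N=C/c3ccccc3)cc2F)ccn1`: 36300 nM

In a functional assay on U-87MG ATCC cells (Homo sapiens) for cytotoxicity, read by MTT assay, with a stated time of 72 h (a higher number here means a weaker inhibitor, a lower number a stronger inhibitor), compound 1 reaches only the limit of the assay, > 100000 nM, so no number is known for it. Compound 4 `CN(C)CCn1cnnc1-c1cc(Oc2ccc(NC(=O)N/N=C/c3ccccc3)cc2F)ccn1` differs from compound 1 by hydrogen in place of hydroxy on an aromatic carbon. Among the compounds with values here, the only measured step that touches the same part of the molecule is an at least 140-fold lower number from compound 1 to compound 2 (2.16 log units; beyond the scatter), where a different group on that carbon with a double bond to nitrogen took the value from the limit of > 100000 nM in this assay, at which 1 of the 3 values shown sits, to a clear number. Within the data shown here, compound 3 carries the same phenyl group as compound 4, though it differs from compound 4 elsewhere and no step between them has been measured; in this assay compound 3 gives 36300 nM. Since compound 1 sits at the limit, the size of the change cannot be computed; the direction is expected to be toward a lower number, but the extent remains to be seen.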

Compound 4, half-maximal inhibitory concentration: 2250 nM
Compound 4: middle estimate off by 13-fold (1.12 log units), on the high side; measured number outside the range, below it.
By their numbers in this assay, from the lowest: compound 2; then compound 4; then compound 3. At a limit, above all of these: compound 1.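

In this assay, compound 1 gives only a limit of the assay, > 100000 nM, not a number. Replacing the hydroxy on the aromatic ring with hydrogen gives an at least 44-fold lower number from compound 1 to compound 4 (1.64 log units; beyond the scatter), so a plain phenyl reaches a clear number without the 1H-indol-3-yl group, although that group still gives the lower value, with a 3.3-fold higher number from compound 2 to compound 4 (0.51 log units; beyond the scatter). Compound 4 also shows that the other end of the molecule matters in this series, with a 16-fold lower number from compound 3 to compound 4 (1.21 log units; beyond the scatter) when (dimethylamino)methyl replaces hydrogen on the saturated chain carbon bound to an aromatic nitrogen.

The compounds shown leave open whether a methoxy group or a fluorine atom in place of that hydroxy would behave like hydrogen. They also leave open whether a longer chain or a cyclic amine would change the value further.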